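The source may hold more compounds than are shown below. What is called first, only, known or untested is meant among the compounds shown, and "the series" means these compounds.

Values so far in a functional assay, read by spectrophotometry, with a stated time of 5 min; a higher number here means a weaker inhibitor, a lower number a stronger inhibitor
- compound 1 `COc1cc(/C=C/C(=O)C(=Cc2ccc(O)c(O)c2)C(=O)/C=C/c2ccc(O)c(OC)c2)ccc1O`: 10400000 nM
- compound 2 `CCOc1cc(/C=C/C(=O)C(=Cc2ccc(O)cc2)C(=O)/C=C/c2ccc(O)c(OCC)c2)ccc1O`: 48000000 nM

Compound 2 stands highest of the two, making it the weaker inhibitor, and the gap down to compound 1 lies beyond the usual scatter. Compound 3 `CCOc1cc(/C=C/C(=O)C(=Cc2ccccc2)C(=O)/C=C/c2ccc(O)c(OCC)c2)ccc1O` is the next compound to be read. It follows from compound 2 by one change, (hydrogen in place of hydroxy on an aromatic carbon), with hydrogen in place of hydroxy on an aromatic carbon, para to a large group, so that 4-hydroxyphenyl becomes phenyl.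

Going by the values given here, no measured pair differs in one place only, so no step shows the size of this change directly. Compound 1 at 10400000 nM and compound 2 at 48000000 nM show only the spread of the two numbers, not the effect of this hydroxy alone. The direction is therefore a tentative expectation: a modest move to a higher number in this assay, near or somewhat beyond the scatter. The expected change is a 1.9-fold higher number from compound 2 to compound 3 (0.27 log units; within the scatter), an estimate with wide uncertainty. For compound 3 the estimated value is 90000000 nM, with an expected range from 25000000 nM to 300000000 nM as the likely span.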

Compound 3, half-maximal inhibitory concentration: 91400000 nM
Estimate against measurement, compound 3: 1.0-fold (0.01 log units) below; measured number inside the range.
By their numbers in this assay, from the lowest: compound 1; then compounds 2 and 3 (each within the scatter of the next).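

In this assay, the series now has its first step that differs in one place: a 1.9-fold higher number from compound 2 to compound 3 (0.28 log units; within the scatter), with hydrogen in place of hydroxy on an aromatic carbon, para to a large group. This step stays within the scatter, so 4-hydroxyphenyl and phenyl cannot be told apart at this position in this assay, and the step gives no sign that this hydroxy matters to the read-out. No supporting data bear on why this is so.

Compound 1 differs from compound 2 and compound 3 in more than one place, so its steps to them cannot be read and its value cannot be assigned to any single group. Going by these compounds, it also remains open whether another group on this same aromatic carbon, such as an amine or a carboxylic acid, would give a step beyond the scatter, and whether the hydroxy groups elsewhere on the shared core would prove as silent as this one.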